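Pyrazole nitrogen substituent and antiproliferative effect

The source may report more compounds than this note shows. Statements on the series, on what has been measured and on what is new or still open speak of the compounds shown alone.

In a functional assay on MV4-11 cells (Homo sapiens) for antiproliferative activity, with a stated time of 6 days, tested at 1.56 uM (on this read-out higher numbers stand for a stronger effect at the one concentration tested and lower numbers for a weaker effect), the three measured compounds give:
compound 1 `CNC(=O)N1CCCc2ccc(NC(=O)c3cccc(-c4cnn(C)c4)c3)cc21`: 71.2%
compound 2 `CNC(=O)N1CCCc2ccc(NC(=O)c3cccc(-c4cc[nH]n4)c3)cc21`: 27.3%
compound 3 `CNC(=O)N1CCCc2ccc(NC(=O)c3cccc(-c4cnn(S(C)(=O)=O)c4)c3)cc21`: 1.6%

Compound 3 stands lowest of the three, with the steps of a number 69.6 percentage points lower from compound 1 to compound 3 (beyond the scatter) and a number 25.7 percentage points lower from compound 2 to compound 3 (beyond the scatter) both beyond the scatter. Compound 4 `CNC(=O)N1CCCc2ccc(NC(=O)c3cccc(-c4cnn(C(C)=O)c4)c3)cc21` differs from compound 3 by acetyl in place of methylsulfonyl on an aromatic nitrogen. For the measured compounds named here, no measured step exchanges acetyl for any group; the only step touching the aromatic nitrogen is a number 69.6 percentage points lower from compound 1 to compound 3 (beyond the scatter), where methylsulfonyl replaced methyl. Whether acetyl recovers part of that loss is not settled by the data, so only a small rise, possibly within the scatter, is expected. For compound 4 the estimate in this assay is 15%, range 0% to 45%. The expected step is a number 13.4 percentage points higher from compound 3 to compound 4 (beyond the scatter).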

Compound 4, a percentage reported as inhibition, at one concentration (the size of the read-out at that concentration, not a potency): 33.6%
Beside the measured number, compound 4's estimate is 18.6 percentage points below it; the measured number falls inside the stated range.
By their numbers in this assay, from the lowest: compound 3; then compounds 2 and 4 (each within the scatter of the next); then compound 1.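

Acetyl in place of methylsulfonyl on the aromatic nitrogen gives a number 32 percentage points higher from compound 3 to compound 4 (beyond the scatter), so in this assay the loss seen with methylsulfonyl does not apply to every group other than methyl at this position. Acetyl still falls short of methyl, with a number 37.6 percentage points lower from compound 1 to compound 4 (beyond the scatter), which makes this only a partial recovery. Against the unsubstituted pyrazole, the result is a number 6.3 percentage points higher from compound 2 to compound 4 (within the scatter), so these two compounds cannot be ranked.

Going by these compounds, whether a longer acyl chain such as propionyl or an aminoethyl group on this nitrogen would match methyl remains open. No measurement at hand accounts for these steps.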